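Ring-nitrogen substituent on the camphor-derived aminoester series

The source may hold more compounds than are shown below. What is called first, only, known or untested is meant among the compounds shown, and "the series" means these compounds.

Compound 2 `CN1CCN(CC(=O)O[C@@H]2C[C@@H]3CC[C@@]2(C)C3(C)C)CC1` gives 103000 nM in an ADME assay on MDCK cells (Canis lupus familiaris) for cytotoxicity, read by MTT assay, with a stated time of 48 h; a higher number here means that more compound is tolerated, a lower number that less compound is tolerated. Among the three measured members it stands second highest; compound 1 `CCN1CCN(CC(=O)O[C@@H]2C[C@@H]3CC[C@@]2(C)C3(C)C)CC1`, which gives 100000 nM in this assay, lies within the scatter of it, while compound 3 `CC1(C)[C@H]2CC[C@]1(C)[C@H](OC(=O)CN1CCCC1)C2`, with 302000 nM in this assay, lies furthest away. The two measured steps are a 1.0-fold higher number from compound 1 to compound 2 (0.01 log units; within the scatter) and a 2.9-fold higher number from compound 2 to compound 3 (0.47 log units; beyond the scatter).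

Compound 4 `CCOC(=O)N1CCN(CC(=O)O[C@@H]2C[C@@H]3CC[C@@]2(C)C3(C)C)CC1` differs from compound 2 by ethoxycarbonyl in place of methyl on an amine nitrogen in a ring. For the measured compounds named here, the step that bears on this site is the one between compound 1 and compound 2, where a change on the same ring nitrogen region gave a 1.0-fold higher number from compound 1 to compound 2 (0.01 log units; within the scatter). The step to compound 3 changes the ring itself and carries less weight here. With only a within-scatter precedent at the ring nitrogen, no step beyond the scatter is expected in this assay, so the expected step is a 1.0-fold lower number from compound 2 to compound 4 (0.01 log units; within the scatter). Compound 4 is therefore estimated at 100000 nM in this assay, with a range from 45000 nM to 220000 nM.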

Compound 4, half-maximal cytotoxic concentration: > 852000 nM
Compound 4 ended at the assay's limit (the forecaster's own chance of this, stated with the estimate: 15%); at least 8.5-fold (0.93 log units) between middle value and limit.
By their numbers in this assay, from the lowest: compounds 1 and 2 (each within the scatter of the next); then compound 3. At a limit, above all of these: compound 4.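

In this assay compound 4 gives > 852000 nM, a limit of the assay and not a number. The substituent on the ring nitrogen made no difference between ethyl and methyl, a 1.0-fold higher number from compound 1 to compound 2 (0.01 log units; within the scatter), but ethoxycarbonyl in place of methyl gives an at least 8.2-fold higher number from compound 2 to compound 4 (0.91 log units; beyond the scatter), and ethoxycarbonyl in place of ethyl gives an at least 8.5-fold higher number from compound 1 to compound 4 (0.93 log units; beyond the scatter). This position therefore carries a larger step than the ring exchange, a 2.9-fold higher number from compound 2 to compound 3 (0.47 log units; beyond the scatter), and what the two alkyl groups showed does not extend to ethoxycarbonyl.

From the compounds shown here alone, the true value of compound 4 stays unknown, so both new steps have only a lower bound. Going by these compounds, whether the step follows the carbonyl or the ethoxy part stays open, and an acetyl group, the unsubstituted ring amine or a longer alkoxycarbonyl chain on the same nitrogen would help to separate them.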